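The source may hold more compounds than are shown below. What is called first, only, known or untested is meant among the compounds shown, and "the series" means these compounds.

Measured compounds and their values:

compound 1, `CCC(=O)N1CC2CC(C1)N2`: 98%
compound 2, `O=C([C@H]1C[C@@H]1F)N1CC2CC(C1)N2`: 100%
compound 3, `O=C([C@@H]1C[C@H]1F)N1CC2CC(C1)N2`: 110%

All three were read in an assay on SH-EP1 cells for agonist activity at Neuronal acetylcholine receptor; alpha4/beta2 (Homo sapiens), read by FLIPR and calcium flux; a higher number here means a larger maximal response, a lower number a smaller maximal response. Of the three numbers, that of compound 3 is the largest; against compound 2 this amounts to a number 10 percentage points higher from compound 2 to compound 3 (within the scatter), against compound 1 to a number 12 percentage points higher from compound 1 to compound 3 (beyond the scatter). Compound 4, `C[C@H]1C[C@H]1C(=O)N1CC2CC(C1)N2`, differs from compound 3 in one place: 2-methylcyclopropyl in place of 2-fluorocyclopropyl on a carbonyl carbon. Among the compounds with values here, the steps that bear on this change are the two earlier swaps of the group on the carbonyl carbon: a number 2 percentage points higher from compound 1 to compound 2 (within the scatter) and a number 12 percentage points higher from compound 1 to compound 3 (beyond the scatter). Both swaps left the largest response close to that of the reference, and only one of them moved beyond the scatter, and then only modestly. Exchanging one small group for another on the same carbonyl carbon is therefore expected to give no step beyond the scatter; the expected step is a number 7 percentage points lower from compound 3 to compound 4 (within the scatter). Compound 4 is estimated at 103%, with a range from 88% to 118%.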

Compound 4, largest response reached (Emax), in percent of the reference or control that the assay uses: 87%
For compound 4 the middle estimate is 16 percentage points above the measured one; the measured number lies below the stated range.
By their numbers in this assay, from the lowest: compound 4; then compounds 1, 2 and 3 (each within the scatter of the next, the first and the last beyond it).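

In this assay, the group on this carbonyl carbon turns out to matter: 2-methylcyclopropyl gives a number 23 percentage points lower from compound 3 to compound 4 (beyond the scatter) and a number 13 percentage points lower from compound 2 to compound 4 (beyond the scatter), and against the ethyl group it gives a number 11 percentage points lower from compound 1 to compound 4 (beyond the scatter) as well. Compound 4 is thus the only one of the four that stands apart from all the others, although 2-methylcyclopropyl and 2-fluorocyclopropyl have the same count of heavy atoms and the same three-membered ring, so that count alone does not set the maximal response. Nothing shown here accounts for the lower response of compound 4.

On these data alone, it remains open whether another configuration of 2-methylcyclopropyl would give the same response. As far as these compounds go, it is also open how a cyclobutyl or 2-hydroxycyclopropyl group would behave on this carbonyl carbon.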